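Chloro-to-amino swap on the shared core

A few compounds are considered here, and "the series" means these few. Any claim that something is new, unique, unknown or untested is made for them only; others in the source may bear on it.

Measured compounds:
- compound 1 `ClCc1ccccc1Cn1cnc2c(Cl)nc(Cl)nc21`: 4160 nM
- compound 2 `Nc1nc(Cl)c2ncn(Cc3ccc(CCl)cc3)c2n1`: 69200 nM
- compound 3 `ClCc1ccccc1Cn1cnc2ncnc(Cl)c21`: 25100 nM

In a functional assay on BT-549 cells (Homo sapiens) for cytotoxicity, read by sulforhodamine B assay, with a stated time of 48 h (a lower number here means that less compound is tolerated, a higher number that more compound is tolerated), compound 1 gives 4160 nM, the lowest of the three numbers; compound 3 sits at 25100 nM and compound 2 at 69200 nM, both beyond the scatter from compound 1. Compound 4 `Nc1nc(Cl)c2ncn(Cc3ccccc3CCl)c2n1` is not yet measured; it differs from compound 1 by amino in place of chloro on an aromatic carbon. For the measured compounds named here, no measured pair isolates this exact change, but compound 2, which also carries the amino group, and compound 3 both give higher numbers than compound 1. The step from compound 1 to compound 4 is therefore expected to be an increase, estimated at a 7.2-fold higher number from compound 1 to compound 4 (0.86 log units; beyond the scatter). For compound 4 in this assay the expected value is 30000 nM, with a range from 8000 nM to 120000 nM.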

Compound 4, concentration lethal to 50% of the cells: 57500 nM
Estimate against measurement, compound 4: 1.9-fold (0.28 log units) below; low and high end bracket the measured number.
By their numbers in this assay, from the lowest: compound 1; then compound 3; then compounds 4 and 2 (each within the scatter of the next).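

In this assay the first step read at this position is large: amino in place of chloro on the aromatic carbon between two ring nitrogen atoms gives a 14-fold higher number from compound 1 to compound 4 (1.14 log units; beyond the scatter) on the shared core. Compound 4 at 57500 nM and compound 2 at 69200 nM lie within the scatter of each other. Nothing measured here explains the step.

Going by these compounds, whether a methoxy or dimethylamino group on this carbon would give a step of similar size remains open.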